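The source may hold more compounds than are shown below. What is called first, only, known or untested is meant among the compounds shown, and "the series" means these compounds.

Going by the values given here, compound 1 `CCc1ccccc1OC(C)C1=NCCN1` gives 10000 nM in a functional assay on CHO cells for agonist activity at Alpha-2B adrenergic receptor (Homo sapiens) (on this read-out lower numbers stand for an effect already at smaller amounts and higher numbers for an effect only at larger amounts of compound), the second highest of the three numbers measured so far. Compound 2 `CCOc1ccccc1OC(C)C1=NCCN1` gives 3160 nM in this assay, and compound 3 `COc1ccccc1OC(C)C1=NCCN1` gives 100000 nM. The two measured replacements of the ethyl of compound 1 pull in opposite directions: a 3.2-fold lower number from compound 1 to compound 2 (0.50 log units; beyond the scatter), whereas a 10-fold higher number from compound 1 to compound 3 (1.00 log units; beyond the scatter). Compound 4 `CC(Oc1ccccc1S(C)(=O)=O)C1=NCCN1` differs from compound 1 by methylsulfonyl in place of ethyl on an aromatic carbon. Neither measured step places methylsulfonyl on this aromatic carbon, and the two known replacements of ethyl already cover a wide span, so their bearing on the new change is loose. A modest rise in this assay is expected for compound 4, a 2.0-fold higher number from compound 1 to compound 4 (0.30 log units; within the scatter). The estimate for compound 4 is 20000 nM, with a range from 4000 nM to 100000 nM.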

Compound 4, half-maximal effective concentration: 10000 nM
The estimate for compound 4 lay 2.0-fold (0.30 log units) above the measured number; the measured number falls inside the stated range.
By their numbers in this assay, from the lowest: compound 2; then compounds 1 and 4 (each within the scatter of the next); then compound 3.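

In this assay, methylsulfonyl on this aromatic carbon gives no change at the digits printed from compound 1 to compound 4 (within the scatter), so replacing ethyl with a group of 4 heavy atoms and 2 hydrogen-bond acceptors leaves the number unmoved. Against the oxygen-linked groups, the same position shows a 10-fold lower number from compound 3 to compound 4 (1.00 log units; beyond the scatter) and also a 3.2-fold higher number from compound 2 to compound 4 (0.50 log units; beyond the scatter), placing methylsulfonyl inside the span set by methoxy and ethoxy. No measurement shown accounts for these steps.

As far as these compounds go, whether an amine, a carboxylic acid or a propoxy chain on this aromatic carbon would stay within that span remains open.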